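Swapping the ring on the piperazine nitrogen, one halogen at a time

The compounds below may be only part of what the source reports. "The series", "measured", "known", "first", "only" and "open" are said of these compounds alone.

Three analogues sharing the core of compound 1 `Nc1scc(CN2CCN(c3cc(Cl)cc(Cl)c3)CC2)c1C(=O)c1ccc(Cl)cc1` have been tested in a functional assay on CHO cells with adenosine receptor A1 (Homo sapiens) as the target, read by cAMP accumulation and immunoassay, with a stated time of 6 min, tested at 0.01 uM; on this read-out lower numbers stand for a stronger effect and higher numbers for a weaker effect at the one concentration tested. Compound 1 gives -1%. Compound 2 `Nc1scc(CN2CCN(c3ccc(Cl)cc3F)CC2)c1C(=O)c1ccc(Cl)cc1` gives -9.2%, and compound 3 `Nc1scc(CN2CCN(c3ccncc3)CC2)c1C(=O)c1ccc(Cl)cc1` gives -4%. The step of a number 8.2 percentage points lower from compound 1 to compound 2 (within the scatter) and the step of a number 3 percentage points lower from compound 1 to compound 3 (within the scatter) both stay inside the scatter, so compound 1 cannot be set apart from the other two on these numbers. Compound 4 `Nc1scc(CN2CCN(c3ccccc3F)CC2)c1C(=O)c1ccc(Cl)cc1` carries 2-fluorophenyl in place of 3,5-dichlorophenyl on an amine nitrogen in a ring. The two earlier exchanges at this same position bear directly on it, and neither moved the read-out beyond the scatter. The expected step of a number 2 percentage points lower from compound 1 to compound 4 (within the scatter) is therefore none beyond the scatter. Compound 4 is estimated at -3%, expected between -13% and 7%.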

Compound 4, a percentage reported as activity, at one concentration (the size of the read-out at that concentration, not a potency): 2.1%
Compound 4: middle estimate off by 5.1 percentage points, on the low side, and the stated range covers the measured number.
By their numbers in this assay, from the lowest: compounds 2, 3, 1 and 4 (each within the scatter of the next, the first and the last beyond it).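

In this assay, 2-fluorophenyl on this ring nitrogen gives a number 3.1 percentage points higher from compound 1 to compound 4 (within the scatter) and a number 6.1 percentage points higher from compound 3 to compound 4 (within the scatter), so neither exchange sets the compounds in those pairs apart. Hydrogen in place of chloro on an aromatic carbon gives a number 11.3 percentage points higher from compound 2 to compound 4 (beyond the scatter), the first modest step beyond the scatter among these compounds. Nothing available explains this step. From the compounds shown here alone, it remains open whether a methoxy group on the phenyl ring, or an acetyl group on the ring nitrogen in place of the aromatic ring, would move the read-out beyond the scatter.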